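Benzylthio variation on the sulfonyl-hydroxyguanidine series

The source may hold more compounds than are shown below. What is called first, only, known or untested is meant among the compounds shown, and "the series" means these compounds.

Measured so far in a functional assay on SNB-75 cells (Homo sapiens); on this read-out higher numbers stand for weaker inhibition of growth and lower numbers for stronger inhibition of growth:
compound 1 `COc1cc(CSc2cc(Cl)c(-c3nnc(-c4ccc(Cl)cc4)s3)cc2S(=O)(=O)NC(=N)NO)cc(OC)c1OC` gives 25700 nM
compound 2 `COc1cc(CSc2cc(Cl)c(-c3nc(-c4ccccc4)no3)cc2S(=O)(=O)NC(=N)NO)cc(OC)c1OC` gives 3980 nM
compound 3 `COc1cc(CSc2cc(Cl)c(-c3nnc(-c4ccccc4)s3)cc2S(=O)(=O)NC(=N)NO)cc(OC)c1OC` gives 1860 nM

Compound 2 stands second highest of the three numbers in this assay; its nearest neighbour is compound 3 with a 2.1-fold lower number from compound 2 to compound 3 (0.33 log units; beyond the scatter), and furthest is compound 1 with a 6.5-fold lower number from compound 1 to compound 2 (0.81 log units; beyond the scatter). The other measured step, a 14-fold lower number from compound 1 to compound 3 (1.14 log units; beyond the scatter), is the largest of the three.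

Compound 4 `N=C(NO)NS(=O)(=O)c1cc(-c2nc(-c3ccccc3)no2)c(Cl)cc1SCc1ccccc1` is compound 2 with phenyl in place of 3,4,5-trimethoxyphenyl on a saturated chain carbon bound to a sulfur. Among the measured compounds shown here, none of the measured steps touches this part of the molecule: all three alter the heteroaryl substituent or the chloro on it, while the benzylthio side remains constant across compounds 1, 2 and 3. For the measured compounds named here, there is therefore no measured step that bears on the change from compound 2 to compound 4, and the direction of the effect in this assay cannot be read from the series. As a working expectation, compound 4 is estimated to stay close to compound 2, with a wide range on either side; the estimated step is a 1.0-fold higher number from compound 2 to compound 4 (0.00 log units; within the scatter). Compound 4 is expected at about 4000 nM, within 1000 nM to 16000 nM.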

Compound 4, concentration for 50% growth inhibition: 1220 nM
Beside the measured number, compound 4's estimate is 3.3-fold (0.52 log units) above it; the range from low to high includes it.
By their numbers in this assay, from the lowest: compounds 4 and 3 (each within the scatter of the next); then compound 2; then compound 1.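

In this assay, the change on the saturated chain carbon bound to a sulfur gives a 3.3-fold lower number from compound 2 to compound 4 (0.51 log units; beyond the scatter), the first measured read on this side of the molecule, and it shows that the number responds here as well as at the heteroaryl substituent. The 3,4,5-trimethoxyphenyl, with its 12 heavy atoms and 3 hydrogen-bond acceptors, is not required for growth inhibition in this pair: the plain phenyl, with 6 heavy atoms and no hydrogen-bond acceptors, gives the lower number. Nothing at hand explains the step, and it is not possible to say which feature of the exchanged groups accounts for it.

On these data alone, the finding rests on a single pair carrying the 3-phenyl-1,2,4-oxadiazol-5-yl group, so it remains open whether the same exchange would lower the number on compound 3 or on compound 1. Also open, as far as these compounds go, is how a 4-methoxyphenyl, which would separate the effect of a single methoxy group from that of all three, or a cyclohexyl in the same place would read in this assay.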